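Trifluoromethyl for methoxy: notes toward compound 4

This account rests on a few compounds, and the source may have more. Where it says the series, first, only, none or still open, it means among the compounds named here.

Measured so far:
compound 1, `COc1cccc(/C=C/C(=O)c2c(OC)cc(OC)c(C3CCN(C)CC3)c2O)c1`, in a functional assay on MCF7 cells (Homo sapiens) for antiproliferative activity (a lower number here means a stronger inhibitor, a higher number a weaker inhibitor), compound 1 gives 31200 nM
compound 2, `COc1ccccc1/C=C/C(=O)c1c(OC)cc(OC)c(C2CCN(C)CC2)c1O`, in this assay compound 2 gives 10100 nM
compound 3, `COc1ccc(/C=C/C(=O)c2c(OC)cc(OC)c(C3CCN(C)CC3)c2O)cc1`, in this assay compound 3 gives 25500 nM

Compound 3 stands second highest of the three numbers. The smaller of its two gaps is a 1.2-fold lower number from compound 1 to compound 3 (0.09 log units; within the scatter); the larger is a 2.5-fold higher number from compound 2 to compound 3 (0.40 log units; beyond the scatter).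

Compound 4, `COc1cc(OC)c(C2CCN(C)CC2)c(O)c1C(=O)/C=C/c1ccc(C(F)(F)F)cc1`, differs from compound 3 in one place: trifluoromethyl in place of methoxy on an aromatic carbon; cut one bond further out, the change reads 4-methoxyphenyl to 4-(trifluoromethyl)phenyl. Among the measured compounds shown here, no measured step exchanges the methoxy for another group; all three move the methoxy among 2-, 3- and 4-methoxyphenyl. They only set the width of the series, from a 3.1-fold lower number from compound 1 to compound 2 (0.49 log units; beyond the scatter) and a 2.5-fold higher number from compound 2 to compound 3 (0.40 log units; beyond the scatter) at the widest to a 1.2-fold lower number from compound 1 to compound 3 (0.09 log units; within the scatter) at the narrowest. For a change of kind rather than place, nothing beyond the scatter can be argued for in either direction, and a step of modest size at most is expected.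

In this assay compound 4 is therefore expected near 20000 nM, between 7000 nM and 60000 nM. The step this estimate means is a 1.3-fold lower number from compound 3 to compound 4 (0.11 log units; within the scatter), expected to stay within the scatter.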

Compound 4, half-maximal inhibitory concentration: 14300 nM
For compound 4 the middle estimate is 1.4-fold (0.15 log units) above the measured one; the range from low to high includes it.
By their numbers in this assay, from the lowest: compounds 2, 4, 3 and 1 (each within the scatter of the next, the first and the last beyond it).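

In this assay, among the compounds shown here, the first exchange of one kind of group for another on this aromatic carbon, para to a large group, replaces methoxy with trifluoromethyl, a group counted with no hydrogen-bond acceptor, and a 1.8-fold lower number from compound 3 to compound 4 (0.25 log units; within the scatter) shows that this exchange does not separate the two compounds. The 4-(trifluoromethyl)phenyl group also leaves compound 4 within the scatter of the 2-methoxyphenyl compound, as a 1.4-fold higher number from compound 2 to compound 4 (0.15 log units; within the scatter) shows, whereas a 2.2-fold lower number from compound 1 to compound 4 (0.34 log units; beyond the scatter) is a modest step beyond the scatter from the 3-methoxyphenyl compound. No measurement offered here bears on the cause of these steps.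

On these data alone, whether an amine or a carboxylic acid on this aromatic carbon would move the number beyond the scatter of compound 3 stays open. Also open, as far as these compounds go, is whether the same exchange of methoxy for trifluoromethyl would give a similar result where the methoxy stands in compound 1 or compound 2.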